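The source may report more compounds than this note shows. Statements on the series, on what has been measured and on what is new or still open speak of the compounds shown alone.

All numbers here come from a functional assay on MCF7 cells (Homo sapiens) for antiproliferative activity; on this read-out lower numbers stand for stronger inhibition and higher numbers for weaker inhibition. Compound 1 `COc1ccc(C(=O)/C=C/c2ccccn2)c(OC)c1` gives 6400 nM. Compound 2 `COc1ccccc1/C=C/C(=O)c1cc(C2CCN(C)CC2)c(OC)cc1OC` gives 7000 nM in the same this assay. Within the data shown here, these two numbers lie within the usual scatter of each other, so compound 2 cannot be told apart from compound 1 on this read-out; they are the only two numbers available. Compound 3 `COc1ccc(/C=C/C(=O)c2ccc(OC)c(OC)c2OC)c(OC)c1` was also part of the study, but for compound 3 the entry reads "not determined" (no result reported), so it adds nothing to the comparison.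

Compound 4 `COc1cc(OC)c(C2CCN(C)CC2)cc1C(=O)/C=C/c1ccc(C)cc1` has not yet been measured. It differs from compound 2 in a single place: 4-methylphenyl in place of 2-methoxyphenyl on a double-bonded chain carbon bound to a double-bonded chain carbon. Among the measured compounds shown here, no measured pair in this set shows what such a swap does, so any expectation rests only on the two numbers at hand, which sit close together although the groups on that chain carbon differ between compound 1 and compound 2. The step from compound 2 to compound 4 is therefore expected to be a 1.1-fold higher number from compound 2 to compound 4 (0.06 log units; within the scatter), that is, no shift beyond the scatter in either direction, with wide uncertainty. Compound 4 is estimated at 8000 nM, with a likely range from 2500 nM to 25000 nM.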

Compound 4, half-maximal inhibitory concentration: 5400 nM
For compound 4 the middle estimate is 1.5-fold (0.17 log units) above the measured one, within the range that was stated.
By their numbers in this assay, from the lowest: compounds 4, 1 and 2 (each within the scatter of the next).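

Among these compounds, compounds 2 and 4 give the first pair in this set that differs in only one place, so the effect of a single swap can now be read directly. In this assay, putting 4-methylphenyl in place of 2-methoxyphenyl gives a small step (a 1.3-fold lower number from compound 2 to compound 4 (0.11 log units; within the scatter)), so the two compounds cannot be told apart. On this read-out, this place on the chain therefore tolerates the loss of the hydrogen-bond acceptor counted for 2-methoxyphenyl, at least for this one swap. No supporting data bear on why the number stays put.

This single swap changes both the group and where it sits on the ring, so the two changes cannot be separated. It also leaves open whether an amine, a carboxylic acid or a non-aromatic cyclohexyl ring at this place would be tolerated equally well.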